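Naphthyl Tetrahydropyran Acid and Its Alcohol Counterpart

The compounds below may be only part of what the source reports. "The series", "measured", "known", "first", "only" and "open" are said of these compounds alone.

Measured compounds:
compound 1, `CC[C@@H]1CCC[C@H](C(=O)O)O1`: 14.1%
compound 2, `O=C(O)[C@H]1CCC[C@@H](c2cccc3ccccc23)O1`: 49%

In a functional assay on the whole organism (Abdomen, strain Swiss albino) for inhibition, with Mus musculus as the target, in the writhing test, with a stated time of 30 min, at a dose of 30 mg/kg by the oral route (on this read-out lower numbers stand for less inhibition and higher numbers for more inhibition at the one dose given (going by the name of the read-out)), compound 1 gives 14.1%. In this assay compound 2 gives 49%, the higher of the two numbers, and its gap to compound 1 lies beyond the usual scatter of this measurement. Compound 3, `OC[C@H]1CCC[C@@H](c2cccc3ccccc23)O1`, has not yet been tested. It differs from compound 2 in one place: hydroxymethyl in place of carboxy on a saturated ring carbon. The change sits on a saturated ring carbon of the shared core, while the large naphthalene group and the ring oxygen stay as they are in compound 2.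

Going by the values given here, with only two measured compounds, there is no step between compounds that differ in a single place to lean on. Compound 3 is expected to fall below compound 2, a downward step of a number 19 percentage points lower from compound 2 to compound 3 (beyond the scatter) that would reach beyond the scatter. For compound 3 the estimated inhibition is 30%, with a range from 10% to 50%.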

Compound 3, a percentage reported as inhibition, in the whole organism at one dose (the size of the read-out at that dose, not a potency): 39.2%
The estimate for compound 3 lay 9.2 percentage points below the measured number; the measured number falls inside the stated range.
By their numbers in this assay, from the lowest: compound 1; then compounds 3 and 2 (each within the scatter of the next).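

In this assay the exchange of carboxy for hydroxymethyl on a saturated ring carbon, next to the ring oxygen, comes with a number 9.8 percentage points lower from compound 2 to compound 3 (within the scatter) and so does not separate the two groups at this position. Compound 2 had left open whether its carboxy was needed for its number, and compound 3 shows that, at this one dose, a compound without carboxy reads within the scatter of it. Nothing shown gives a reason for this result.

As far as these compounds go, it remains open whether an amine, a methyl ester or a primary amide at the same place would read like these two groups. From the compounds shown here alone, it is also open whether the same exchange on compound 1, which lacks the naphthalene group, would read the same way.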